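The source may report more compounds than this note shows. Statements on the series, on what has been measured and on what is new or still open speak of the compounds shown alone.

Working notes on the series. Compound 1 `COc1ccc(C2=Cc3ccc(F)cc3C(CC(C)=O)N2c2ccc(C#N)cc2)cc1` has no result in an ADME assay on TZM cells (Homo sapiens) for cytotoxicity, read by CellTiter-Glo, with a stated time of 48 h; a lower number here means that less compound is tolerated, a higher number that more compound is tolerated ("not determined" (no result reported)). Compound 2 `COc1ccc(C2=Cc3ccc([N+](=O)[O-])cc3C(CC(C)=O)N2c2ccc(F)cc2)cc1` gives 7700 nM in this assay. Compound 3 `COc1ccc(C2=Cc3ccc(F)cc3C(CC(=O)CO)N2c2ccc(C)cc2)cc1` gives 23700 nM in this assay, the highest of the two numbers available; its nearest neighbour is compound 2, and that gap lies beyond the scatter. Going by the values given here, no pair of measured compounds differs in a single place, so no single step has been isolated.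

Compound 4 `COc1ccc(C2=Cc3ccc(F)cc3C(CC(=O)CO)N2c2ccc([N+](=O)[O-])cc2)cc1` is the next entry for this assay. Relative to compound 3 it carries nitro in place of methyl on an aromatic carbon. Nothing in the measured set separates this change from other differences, and no direction has been shown for it.

The expectation for compound 4 is that the change from compound 3 leaves the number somewhat lower, a step of a 1.6-fold lower number from compound 3 to compound 4 (0.20 log units; within the scatter), but one that may well stay within the scatter. Compound 4 is therefore estimated at 15000 nM, with a range from 5000 nM to 45000 nM.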

Compound 4, half-maximal cytotoxic concentration: 46400 nM
For compound 4 the middle estimate is 3.1-fold (0.49 log units) below the measured one; the whole stated range lies below it.
By their numbers in this assay, from the lowest: compound 2; then compounds 3 and 4 (each within the scatter of the next).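

In this assay, going by these compounds alone, nitro in place of methyl on an aromatic carbon, para to a large group, gives a 2.0-fold higher number from compound 3 to compound 4 (0.29 log units; within the scatter) and is the first single-place step that can be read. At this position, 4-nitrophenyl and 4-methylphenyl therefore cannot be told apart in this assay, despite the added heavy atoms and hydrogen-bond acceptors that come with the nitro group. No measurement at hand offers an explanation for this result.

From the compounds shown here alone, what an amine, a carboxylic acid or a longer chain would give at this position remains open. Within the data shown here, also open is whether the same exchange would read alike with a different side chain on the shared core, and compound 2 is still linked to the others by no single-place step.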